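A few compounds are considered here, and "the series" means these few. Any claim that something is new, unique, unknown or untested is made for them only; others in the source may bear on it.

Measured so far in a functional assay on BGC-823 cells (Homo sapiens) for inhibition, read by sulforhodamine B assay, with a stated time of 3 days; on this read-out lower numbers stand for stronger inhibition and higher numbers for weaker inhibition:

- compound 1 `O=C1Nc2ccc([N+](=O)[O-])cc2/C1=C\C(=O)c1ccc(C2CCCCC2)cc1`: 5900 nM
- compound 2 `CN1CCN(c2cccc(N/C=C3\C(=O)Nc4ccc(NC(=O)c5c(F)cccc5F)cc43)c2)CC1`: 2670 nM

Of these two compounds, compound 2 has the lower number at 2670 nM, and so the stronger inhibition. Its gap to compound 1 at 5900 nM lies beyond the usual scatter, although both numbers sit in the low micromolar range. The two compounds differ in more than one place, so this gap says nothing about any single group.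

Compound 3 `CC(C)CC(=O)Nc1ccc2c(c1)/C(=C/Nc1cccc(N3CCN(C)CC3)c1)C(=O)N2` keeps the rest of compound 2 and changes one place, with isobutyl in place of 2,6-difluorophenyl on a carbonyl carbon. The aromatic ring of the departing group is lost, and no ring enters. Among the compounds with values here, no measured pair shows this kind of change, so the only close reference is compound 2 at 2670 nM, and the expectation remains uncertain. A modest move toward weaker inhibition in this assay is expected, though one within the scatter would be no surprise. The estimated step is a 1.5-fold higher number from compound 2 to compound 3 (0.18 log units; within the scatter). For compound 3 the estimated value is 4000 nM, with an expected range of 1300 nM to 13000 nM.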

Compound 3, half-maximal inhibitory concentration: 6080 nM
Beside the measured number, compound 3's estimate is 1.5-fold (0.18 log units) below it; the range from low to high includes it.
By their numbers in this assay, from the lowest: compound 2; then compounds 1 and 3 (each within the scatter of the next).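

Compound 2 and compound 3 are the only pair shown that differ in one place, so they give the first direct reading of the group on this carbonyl carbon. In this assay, putting isobutyl in place of 2,6-difluorophenyl gives a 2.3-fold higher number from compound 2 to compound 3 (0.36 log units; beyond the scatter), so at this position the open chain gives weaker inhibition than the fluorinated aromatic ring, though the step is modest and inhibition is not lost. Nothing measured on these compounds explains the shift.

The pair cannot show whether the aromatic ring or its two fluorines matter more, since the change removes both at once: a plain phenyl on the same carbonyl carbon would separate those two parts, and a cyclohexyl would show whether a ring without aromatic character can serve as well. It also leaves open whether this step would keep its size with other parts of the compound changed, since it rests on a single pair sharing one core.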